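Iodo for fluoro at the para position of compound 3

The source may report more compounds than this note shows. Statements on the series, on what has been measured and on what is new or still open speak of the compounds shown alone.

Measured compounds:
compound 1, `COc1ccccc1Oc1c(N)nc(-c2ccc(C)cc2)nc1Cl`: 17400 nM
compound 2, `COc1ccccc1Oc1c(N)nc(-c2cccc(F)c2)nc1Cl`: 21700 nM
compound 3, `COc1ccccc1Oc1c(N)nc(-c2ccc(F)cc2)nc1Cl`: 2990 nM

In a functional assay on B16 cells (Mus musculus) for cytotoxicity, read by CCK-8 assay, with a stated time of 24 h (a higher number here means a weaker inhibitor, a lower number a stronger inhibitor), compound 3 stands lowest of the three numbers shown. Its nearest neighbour is compound 1, separated by a 5.8-fold lower number from compound 1 to compound 3 (0.76 log units; beyond the scatter), and its furthest is compound 2, separated by a 7.3-fold lower number from compound 2 to compound 3 (0.86 log units; beyond the scatter). Compound 1 and compound 2 lie close together, as a 1.2-fold higher number from compound 1 to compound 2 (0.10 log units; within the scatter) shows.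

Compound 4, `COc1ccccc1Oc1c(N)nc(-c2ccc(I)cc2)nc1Cl`, has not yet been measured. It differs from compound 3 by iodo in place of fluoro on an aromatic carbon. Within the data shown here, of the measured steps, only the one from compound 1 to compound 3 changes the group at this same place, fluoro in place of methyl, and it gave a 5.8-fold lower number from compound 1 to compound 3 (0.76 log units; beyond the scatter). Among the measured compounds shown here, no measured step replaces one halogen by another, so the size of the present change is not anchored by any direct comparison. For the measured compounds named here, the one relevant step shows that what sits at this place can move the number modestly, and the two remaining analogues, compound 1 and compound 2, both lie above compound 3. Compound 4 is therefore expected to come out near compound 3 or somewhat higher, estimated as a 2.0-fold higher number from compound 3 to compound 4 (0.30 log units; within the scatter). Compound 4 is expected to give 6000 nM, with a range from 1500 nM to 20000 nM.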

Compound 4, half-maximal inhibitory concentration: 5400 nM
Compound 4: middle estimate off by 1.1-fold (0.05 log units), on the high side; the measured number falls inside the stated range.
By their numbers in this assay, from the lowest: compounds 3 and 4 (each within the scatter of the next); then compounds 1 and 2 (each within the scatter of the next).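

Among these compounds, compound 4 gives the first exchange of one halogen for another on this aromatic carbon, para to a large group, and in this assay the change from fluoro to iodo stays within the scatter (a 1.8-fold higher number from compound 3 to compound 4 (0.26 log units; within the scatter)). The lower numbers at this place are therefore not confined to fluoro: iodo also separates from methyl (a 3.2-fold lower number from compound 1 to compound 4 (0.51 log units; beyond the scatter)) and from the 3-fluorophenyl analogue (a 4.0-fold lower number from compound 2 to compound 4 (0.60 log units; beyond the scatter)), with both steps beyond the scatter. Among the compounds shown, the two 4-halophenyl compounds, compound 3 and compound 4, sit apart from compound 1, while compound 2 shows that a halogen on the phenyl ring does not by itself give the lower number, and no evidence is available on what lies behind these differences.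

Going by these compounds, whether chloro or bromo at this place would fall with fluoro and iodo remains open, as does the outcome with a methoxy group, an amine or a carboxylic acid there. On these data alone, it is also open whether 3-iodophenyl would follow compound 2, or whether changes to the methoxy group on the other ring would shift these numbers.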